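The compounds below may be only part of what the source reports. "The series", "measured", "known", "first", "only" and "open" are said of these compounds alone.

Working notes on the series. Two compounds of this chalcone–triazole type have been measured in a functional assay on SK-N-SH cells (Homo sapiens) for inhibition, read by MTT assay; a lower number here means a stronger inhibitor, a higher number a weaker inhibitor. Compound 1, `O=C(CN1CCN(c2ccc([N+](=O)[O-])cc2)CC1)Nc1ccc(C(=O)/C=C/c2cn(Cc3ccc(Br)cc3)nn2)cc1`, gives 26500 nM. Within the data shown here, compound 2, `CCCCCCCCCCn1cc(/C=C/C(=O)c2ccc(NC(=O)CN3CCN(C(=O)OC(C)(C)C)CC3)cc2)nn1`, gives 77800 nM, the highest of the two numbers so far; compound 1 sits at a lower number, and the gap between compound 1 and compound 2 is beyond the usual scatter. Compound 1 and compound 2 differ at two places at once, so neither site can be credited with that gap on its own.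

Compound 3, `CCCCCCCCCCn1cc(/C=C/C(=O)c2ccc(NC(=O)CN3CCN(c4ccc([N+](=O)[O-])cc4)CC3)cc2)nn1`, is not yet measured. It keeps the decyl chain of compound 2 and changes only one site: 4-nitrophenyl in place of tert-butoxycarbonyl on an amine nitrogen in a ring. Compound 3 thereby carries the same piperazine substituent as compound 1. Among the measured compounds shown here, a step toward a lower number in this assay is expected, of modest size and possibly no larger than the scatter, since the only guide is the pairing of compound 1 at 26500 nM with compound 2 at 77800 nM across two simultaneous changes. The step expected from compound 2 to compound 3 is a 2.2-fold lower number from compound 2 to compound 3 (0.35 log units; beyond the scatter). Compound 3 is estimated at 35000 nM, within a range from 12000 nM to 100000 nM.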

Compound 3, half-maximal inhibitory concentration: 40900 nM
Compound 3: the middle estimate sits 1.2-fold (0.07 log units) below what was measured; the range from low to high includes it.
By their numbers in this assay, from the lowest: compounds 1, 3 and 2 (each within the scatter of the next, the first and the last beyond it).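

With the decyl chain held fixed, 4-nitrophenyl in place of tert-butoxycarbonyl on the amine nitrogen in the ring gives a 1.9-fold lower number from compound 2 to compound 3 (0.28 log units; within the scatter) in this assay, so the two groups are not told apart at this position. With the 4-nitrophenyl group held fixed, nonyl in place of 4-bromophenyl on the saturated chain carbon bound to an aromatic nitrogen gives a 1.5-fold higher number from compound 1 to compound 3 (0.19 log units; within the scatter), so neither single change is resolved from the scatter. No available evidence bears on these two steps.

As far as these compounds go, each site is so far read against one background only, so it remains open whether the same steps hold with the other group at the second site. Also open, from the compounds shown here alone, is how a free ring amine or an acetyl group on that nitrogen, or a butyl chain or unsubstituted benzyl at the other site, would read.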